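A chloro-to-methoxy swap on compound 3

A few compounds are considered here, and "the series" means these few. Any claim that something is new, unique, unknown or untested is made for them only; others in the source may bear on it.

Compound 1 `CCOC(=O)c1nn(-c2ccccc2)c(-c2ccc(F)cc2)c1CNC(C)(C)C`: 13 nM; 92100 nM (2 entries)
Compound 2 `CCOC(=O)c1nn(-c2ccc(Cl)cc2)c(-c2ccccc2)c1CNC(C)(C)C`: > 608000 nM; > 559000 nM (2 entries)
Compound 3 `CC(C)(C)NCc1c(C(=O)O)nn(-c2ccccc2)c1-c1ccc(Cl)cc1`: > 652000 nM

In a functional assay on OVCAR-3 cells (Homo sapiens) for inhibition, read by sulforhodamine B assay, with a stated time of 48 h (a higher number here means a weaker inhibitor of growth, a lower number a stronger inhibitor of growth), compound 3 gives > 652000 nM, which is a limit of the assay and not a number. Compound 2 also gives only limits, > 608000 nM; > 559000 nM (2 entries). Compound 1 does give numbers, but they disagree widely (the several entries of compound 1 in this assay, 13 nM; 92100 nM (2 entries)), so they offer little firm footing.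

Compound 4 `COc1ccc(-c2c(CNC(C)(C)C)c(C(=O)O)nn2-c2ccccc2)cc1` differs from compound 3 in one place, with methoxy in place of chloro on an aromatic carbon, para to a large group (methoxy in place of chloro on an aromatic carbon). Among the compounds with values here, no two measured compounds differ in a single place, so the data give no direct measure of such a change. No step beyond the scatter is expected in this assay, in either direction. This expectation rests on compound 3, whose > 652000 nM is a limit. The estimated step is an at least 1.0-fold lower number from compound 3 to compound 4 (0.03 log units; that floor lies within the scatter). For compound 4 the expected value is 600000 nM, with an estimated range of 100000 nM to 700000 nM.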

Compound 4, concentration for 50% growth inhibition: > 659000 nM
Compound 4: no number, only a limit (the forecaster's own chance of this, stated with the estimate: 75%); middle value at least 1.0-fold (0.04 log units) from the limit.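

Within the data shown here, compound 3 and compound 4 both give only limits in this assay, so no step between them can be read. The compounds shown leave open whether methoxy in place of chloro changes growth inhibition at all on the shared core.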